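The source may report more compounds than this note shows. Statements on the series, on what has been measured and on what is new or still open speak of the compounds shown alone.

Measured so far:
- compound 1, `N#Cc1c(-c2ccc(Br)cc2)nc2cnccc2c1NCC(N)=O`, with 1.9 in a physicochemical assay for lipophilicity, read by HPLC, at pH 7.5; a higher number here means a more lipophilic compound, a lower number a more polar compound
- compound 2, `CC[C@@H](Nc1c(C#N)c(-c2ccc(-c3cccc(C)c3F)cc2)nc2cnccc12)C(N)=O`, with 3 in this assay

Of these two values, compound 2 holds the higher one; its nearest neighbour is compound 1, whose value lies a good way lower, further apart than the usual scatter of repeated measurements.

Compound 3, `CC[C@@H](Nc1c(C#N)c(-c2ccc(-c3ccccc3N(C)C)cc2)nc2cnccc12)C(N)=O`, has not yet been measured. It differs from compound 2 in one place: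

2-(dimethylamino)phenyl in place of 2-fluoro-3-methylphenyl on an aromatic carbon

Within the data shown here, no measured pair in this set shows a step of the same kind, so the size of the step in this assay can only be guessed. The expectation is a modest move downward, or perhaps no change beyond the scatter; the estimated step from compound 2 to compound 3 is a number 0.30 log units lower from compound 2 to compound 3 (within the scatter). Starting from compound 2 with its 3, compound 3 is therefore expected to give about 2.7, most likely between 2.2 and 3.2.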

Compound 3, distribution coefficient: 3.2
Beside the measured number, compound 3's estimate is 0.50 log units below it, and the stated range covers the measured number.
By their numbers in this assay, from the lowest: compound 1; then compounds 2 and 3 (each within the scatter of the next).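

In this assay, putting 2-(dimethylamino)phenyl in place of 2-fluoro-3-methylphenyl on this aromatic carbon, para to a large group, gives a number 0.20 log units higher from compound 2 to compound 3 (within the scatter). At this position, then, a ring carrying fluorine and methyl and a ring carrying a dimethylamino group cannot be told apart on this read-out, even though the entering group counts one hydrogen-bond acceptor and the leaving group none. Nothing measured alongside these compounds offers an explanation for this result.

With a single change shown at this position, it remains open how a ring carrying a carboxylic acid or a longer amine chain would read in this assay. Whether a plain amine in place of the dimethylamino group would read the same is equally unanswered.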